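This account rests on a few compounds, and the source may have more. Where it says the series, first, only, none or still open, it means among the compounds named here.

Compound 1 `Brc1ccc(C(c2ccccc2)N2CCN(c3ncnc4c3cnn4-c3ccccc3)CC2)cc1` is the reference point of this small set. In a functional assay on cells (Rhabdomyosarcoma cell, Homo sapiens) for cytotoxicity (a higher number here means a weaker inhibitor, a lower number a stronger inhibitor), compound 1 gives > 25000 nM, which is a limit of the assay and not a number. Compound 2 `c1ccc(C(c2ccco2)N2CCN(c3ncnc4c3cnn4-c3ccccc3)CC2)cc1` gives > 25000 nM in this assay, again a limit. Compound 3 `c1ccc(-c2ccc(C(c3ccccc3)N3CCN(c4ncnc5c4cnn5-c4ccccc4)CC3)cc2)cc1` gives > 25000 nM in this assay, also a limit. The whole measured set thus rests at one point: the limit of > 25000 nM in this assay, at which 3 of the 3 values shown sit. Within the data shown here, the steps inside it, a step that the two limits leave unreadable from compound 1 to compound 2, a step that the two limits leave unreadable from compound 1 to compound 3 and a step that the two limits leave unreadable from compound 2 to compound 3, cannot be read in size or direction; the set shows only that exchanges on a saturated chain carbon bound to an amine nitrogen in a ring and an aromatic carbon, and on an aromatic carbon, left the read-out at the limit.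

Compound 4 `c1ccc(C(c2cccnc2)N2CCN(c3ncnc4c3cnn4-c3ccccc3)CC2)cc1` differs from compound 1 in one place: pyridin-3-yl in place of 4-bromophenyl on a saturated chain carbon bound to an amine nitrogen in a ring and an aromatic carbon. No readable measured step bears on this change, so the expectation is that compound 4 remains where the series stands. Compound 4 is expected to give 30000 nM in this assay, within 10000 nM to 100000 nM, most probably reported again as a limit. The expected step that the limit leaves unreadable from compound 1 to compound 4 is accordingly none beyond the scatter.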

Compound 4, half-maximal inhibitory concentration: > 25000 nM
Compound 4 gave a limit, no number; the forecaster's own chance of this, stated with the estimate: 85%; the middle value does not contradict the limit.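

Compound 4 gives > 25000 nM in this assay, a limit and not a number. No step from compound 1, compound 2 or compound 3 to compound 4 can be read, and the series stays at one point: the limit of > 25000 nM in this assay, at which 4 of the 4 values shown sit.

The compounds shown leave open whether any exchange on the saturated chain carbon bound to an amine nitrogen in a ring and an aromatic carbon gives a readable value in this assay.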